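From 4-(dimethylamino)phenyl to pyridin-4-yl on a shared core

A few compounds are considered here, and "the series" means these few. Any claim that something is new, unique, unknown or untested is made for them only; others in the source may bear on it.

Measured in a functional assay on KB-VIN10 cells (Homo sapiens) for inhibition, with a stated time of 72 h; a higher number here means a weaker inhibitor, a lower number a stronger inhibitor:
compound 1 `COc1ccc(S(=O)(=O)N2CCc3cccc(-c4ccco4)c32)cc1`: 79.2 nM
compound 2 `COc1ccc(S(=O)(=O)N2CCc3cccc(-c4ccc([N+](=O)[O-])cc4)c32)cc1`: 51.3 nM
compound 3 `COc1ccc(S(=O)(=O)N2CCc3cccc(-c4ccc(N(C)C)cc4)c32)cc1`: 553 nM

Among these, compound 3 has the highest number and is the weakest inhibitor of the three. The other two do not separate, with a 1.5-fold lower number from compound 1 to compound 2 (0.19 log units; within the scatter).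

Compound 4 `COc1ccc(S(=O)(=O)N2CCc3cccc(-c4ccncc4)c32)cc1` has not yet been measured. It keeps the shared core and carries pyridin-4-yl in place of 4-(dimethylamino)phenyl on an aromatic carbon.

Going by the values given here, two measured steps bear on this change, and both end at the 4-(dimethylamino)phenyl group: a 7.0-fold higher number from compound 1 to compound 3 (0.84 log units; beyond the scatter), and an 11-fold higher number from compound 2 to compound 3 (1.03 log units; beyond the scatter). Among the compounds with values here, neither involves pyridin-4-yl, and no compound carrying that group has a measured number yet, so the size of the coming step remains uncertain. Even so, the other aromatic groups give lower numbers: with furan-2-yl, compound 1 stands at 79.2 nM, and with 4-nitrophenyl, compound 2 stands at 51.3 nM. A move back towards these numbers in this assay is therefore expected, though probably not all the way. The expected change is a 4.3-fold lower number from compound 3 to compound 4 (0.63 log units; beyond the scatter). For compound 4 the estimated value is 130 nM, with an expected range from 45 nM to 400 nM.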

Compound 4, half-maximal inhibitory concentration: 106 nM
Beside the measured number, compound 4's estimate is 1.2-fold (0.09 log units) above it; the range from low to high includes it.
By their numbers in this assay, from the lowest: compounds 2, 1 and 4 (each within the scatter of the next, the first and the last beyond it); then compound 3.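

In this assay, the step with a 5.2-fold lower number from compound 3 to compound 4 (0.72 log units; beyond the scatter) shows that a six-membered aromatic ring with one hetero atom at this place on the shared core does not share the high number of the 4-(dimethylamino)phenyl group, which leaves compound 3 alone as the weakest inhibitor of the four. Pyridin-4-yl does not separate from furan-2-yl, with a 1.3-fold higher number from compound 1 to compound 4 (0.13 log units; within the scatter) lying within the scatter, whereas a 2.1-fold higher number from compound 2 to compound 4 (0.32 log units; beyond the scatter) lies just beyond it and gives the first measured separation among the three groups with the lower numbers, although compound 1 and compound 2 themselves still do not separate. No measurement on hand explains any of these steps.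

The compounds shown leave open whether the higher number of compound 3 belongs to the dimethylamino group itself, since a plain phenyl group, a primary amine or a carboxylic acid on that phenyl ring would be needed to place it. They also leave open whether the pattern among these four compounds holds for any other group at this position or for any cell line other than this one.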